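Dichlorophenyl in place of chlorophenyl on the branched amide

The compounds below may be only part of what the source reports. "The series", "measured", "known", "first", "only" and "open" are said of these compounds alone.

Compound 1 `O=C(CCSc1nnc(-c2ccncc2)s1)Nc1c(Cl)cccc1Cl` and compound 2 `CC(CSc1nnc(-c2ccncc2)s1)C(=O)Nc1ccc(Cl)cc1` share a core and differ in two places, the amide aryl group and the methyl on the chain. In an ADME assay on BHK-21 cells (Mesocricetus auratus) for cytotoxicity, with a stated time of 3 days (on this read-out lower numbers stand for higher toxicity in this test and higher numbers for lower toxicity in this test), compound 1 gives 10300 nM. In this assay compound 2 returns only a limit, > 50000 nM, so no number stands for it. This is the limit of > 50000 nM in this assay, at which 1 of the 2 values shown sits. Compound 3 `CC(CSc1nnc(-c2ccncc2)s1)C(=O)Nc1c(Cl)cccc1Cl` differs from compound 2 by 2,6-dichlorophenyl in place of 4-chlorophenyl on an amide-type nitrogen. For the measured compounds named here, no measured step covers this change alone; the pair of compound 1 and compound 2 shows only a number against a limit, with two changes between them. Compound 1, which also carries the 2,6-dichlorophenyl, gives 10300 nM, which points toward lower numbers. In this assay the step from compound 2 to compound 3 is expected to be an at least 2.0-fold lower number from compound 2 to compound 3 (0.30 log units; that floor lies within the scatter). Compound 3 is estimated at 25000 nM, with a range from 8000 nM to 60000 nM.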

Compound 3, half-maximal cytotoxic concentration: > 50000 nM
Compound 3 ended at the assay's limit; the forecaster's own chance of this, stated with the estimate: 40%; at least 2.0-fold (0.30 log units) between middle value and limit.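

With 2,6-dichlorophenyl on the amide-type nitrogen in both compounds, methyl in place of hydrogen on the saturated chain carbon bound to a carbonyl carbon and a saturated chain carbon gives an at least 4.8-fold higher number from compound 1 to compound 3 (0.68 log units; beyond the scatter) in this assay. The exchange of 4-chlorophenyl for 2,6-dichlorophenyl cannot be read, since compound 2 and compound 3 both end at a limit: the limit of > 50000 nM in this assay, at which 2 of the 3 values shown sit. Of the compounds shown, compound 1 alone gives a number rather than a limit, and it alone lacks the methyl.

From the compounds shown here alone, it remains open whether 4-chlorophenyl on the chain without the methyl also gives a number in this assay. Also open, going by these compounds, is how an ethyl group on that chain carbon, or a longer chain, would read in this assay.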